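Aryl in Place of Methyl on the Ring Imide Nitrogen

This account rests on a few compounds, and the source may have more. Where it says the series, first, only, none or still open, it means among the compounds named here.

Among the measured compounds shown here, compound 2, `CC(C)[C@@H]1CC[C@@H](C)C[C@@]12N(C)C(=O)[C@@H]1[C@H]3C(=O)N(C)C(=O)[C@H]3ON12`, gives 36.5% in a functional assay, read by spectrophotometry, with a stated time of 2 h, tested at 0.5 mg/mL (a higher number here means a stronger effect of the compound at the concentration tested, a lower number a weaker effect), the highest of the three numbers measured so far. For the measured compounds named here, compound 1, `CC(C)[C@@H]1CC[C@@H](C)C[C@@]12N(C)C(=O)[C@@H]1[C@H]3C(=O)NC(=O)[C@H]3ON12`, gives 25.9%, and the step of a number 10.6 percentage points higher from compound 1 to compound 2 (beyond the scatter) is the only step here beyond the scatter. Compound 3, `CC(C)[C@@H]1CC[C@@H](C)C[C@@]12N(C)C(=O)[C@@H]1[C@H]3C(=O)N(c4ccccc4)C(=O)[C@H]3ON12`, gives 28.7%, with the step of a number 2.8 percentage points higher from compound 1 to compound 3 (within the scatter) within the scatter. Compound 4, `COc1ccc(N2C(=O)[C@H]3[C@H](ON4[C@@H]3C(=O)N(C)[C@@]43C[C@H](C)CC[C@H]3C(C)C)C2=O)cc1`, differs from compound 2 by 4-methoxyphenyl in place of methyl on an amide-type nitrogen in a ring. The step that bears most directly on this change is a number 7.8 percentage points lower from compound 2 to compound 3 (within the scatter), which stayed within the scatter, so the expected step of a number 6.5 percentage points lower from compound 2 to compound 4 (within the scatter) is small, downward or none beyond the scatter. Compound 4 is therefore estimated at 30%, between 20% and 40%.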

Compound 4, a percentage reported as activity, at one concentration (the size of the read-out at that concentration, not a potency): 44.5%
Compound 4: the middle estimate sits 14.5 percentage points below what was measured; measured number above the stated range.
By their numbers in this assay, from the lowest: compounds 1, 3, 2 and 4 (each within the scatter of the next, the first and the last beyond it).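

In this assay the methoxy group separates the two aryl compounds (a number 15.8 percentage points higher from compound 3 to compound 4 (beyond the scatter)), a difference that phenyl alone had not opened from the unsubstituted imide. Set against hydrogen on the same ring nitrogen, 4-methoxyphenyl also clears the scatter (a number 18.6 percentage points higher from compound 1 to compound 4 (beyond the scatter)), whereas against methyl it does not (a number 8 percentage points higher from compound 2 to compound 4 (within the scatter)), so aryl has not been separated from methyl at this position. No measurement given here accounts for the methoxy step. As far as these compounds go, whether an amine or a carboxylic acid on the phenyl ring would match methoxy remains open, as does the result of a longer chain on this nitrogen.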